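Removing one fluorine from the benzylsulfonyl group of compound 3

This account rests on a few compounds, and the source may have more. Where it says the series, first, only, none or still open, it means among the compounds named here.

Compound 3 `N#Cc1cc2c(nc1N1CCC(C(=O)NS(=O)(=O)Cc3ccc(F)cc3F)CC1)COC2=O` gives 5200 nM in a functional assay (Platelet, plasma) for inhibition, with Homo sapiens as the target; on this read-out lower numbers stand for stronger inhibition and higher numbers for weaker inhibition. Compound 1 `N#Cc1cc2c(nc1N1CCC(C(=O)NS(=O)(=O)C3(c4ccccc4)CC3)CC1)COC2=O` gives 4100 nM and compound 2 `CC(c1ccccc1)S(=O)(=O)NC(=O)C1CCN(c2nc3c(cc2C#N)C(=O)OC3)CC1` gives 4160 nM; the steps of a 1.3-fold higher number from compound 1 to compound 3 (0.10 log units; within the scatter) and a 1.3-fold higher number from compound 2 to compound 3 (0.10 log units; within the scatter) place compound 3 alongside both. Compound 4 `N#Cc1cc2c(nc1N1CCC(C(=O)NS(=O)(=O)Cc3ccc(F)cc3)CC1)COC2=O` differs from compound 3 by hydrogen in place of fluoro on an aromatic carbon. Among the compounds with values here, no measured step alters a fluoro on that ring; the three steps measured, a 1.0-fold higher number from compound 1 to compound 2 (0.01 log units; within the scatter) among them, exchange whole groups on the sulfonyl sulfur and all stay within the scatter, so a hydrogen for fluoro is expected to move the number no further than the scatter. Compound 4 is therefore estimated at 5200 nM, between 2600 nM and 10400 nM, a step of no change at the digits printed from compound 3 to compound 4 (within the scatter).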

Compound 4, half-maximal inhibitory concentration: 3500 nM
Beside the measured number, compound 4's estimate is 1.5-fold (0.17 log units) above it, within the range that was stated.
By their numbers in this assay, from the lowest: compounds 4, 1, 2 and 3 (each within the scatter of the next).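

In this assay, within the data shown here, the step of a 1.5-fold lower number from compound 3 to compound 4 (0.17 log units; within the scatter) is the first to alter a fluoro on this ring, and going from 2,4-difluorobenzyl to 4-fluorobenzyl stays within the scatter. The 4-fluorobenzyl group also stands level with the other groups on the sulfonyl sulfur, with a 1.2-fold lower number from compound 2 to compound 4 (0.08 log units; within the scatter) and a 1.2-fold lower number from compound 1 to compound 4 (0.07 log units; within the scatter) as the steps. No measurement at hand bears on why this is so.

The compounds shown leave open whether a chloro, a methoxy or an amine on this aromatic carbon, or hydrogen in place of the remaining fluoro, would also stay within the scatter.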